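A few compounds are considered here, and "the series" means these few. Any claim that something is new, unique, unknown or untested is made for them only; others in the source may bear on it.

In a functional assay on MCF7 cells (Homo sapiens) for cytotoxicity, read by MTT assay, with a stated time of 72 h (a lower number here means a stronger inhibitor, a higher number a weaker inhibitor), compound 3 `COc1cc2ncnc(Nc3ccc(F)c(Cl)c3)c2cc1NC(=O)N/N=C/c1ccc(F)cc1` gives 35100 nM, within the scatter of compound 1 `O=C(N/N=C/c1ccc(F)cc1)Nc1cc2c(Nc3ccc(F)c(Cl)c3)ncnc2cc1O[C@H]1CCOC1` at 28200 nM, while compound 2 `CCN(CC)c1ccc(/C=N/NC(=O)Nc2cc3c(Nc4ccc(F)c(Cl)c4)ncnc3cc2O[C@H]2CCOC2)c(O)c1` reads lower at 15600 nM. Compound 4 `COc1cc2ncnc(Nc3ccc(F)c(Cl)c3)c2cc1NC(=O)N/N=C/c1ccc(OC)c(OC)c1OC` keeps the rest of compound 3, but 2,3,4-trimethoxyphenyl replaces 4-fluorophenyl on a carbon with a double bond to nitrogen: 2,3,4-trimethoxyphenyl in place of 4-fluorophenyl on a carbon with a double bond to nitrogen. The closest evidence is a replacement at that same place, a 1.8-fold lower number from compound 1 to compound 2 (0.26 log units; within the scatter). A change elsewhere in the structure, a 1.2-fold higher number from compound 1 to compound 3 (0.10 log units; within the scatter), also stayed small. On these two steps, no change beyond the scatter is expected in this assay. The expected step is a 1.3-fold lower number from compound 3 to compound 4 (0.10 log units; within the scatter). For compound 4 the estimated value is 28000 nM, with an expected range of 13000 nM to 60000 nM.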

Compound 4, half-maximal inhibitory concentration: "not active" (no number reported)
Compound 4 has no reported number here, and the estimate cannot be compared.
By their numbers in this assay, from the lowest: compounds 2, 1 and 3 (each within the scatter of the next, the first and the last beyond it).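

Going by these compounds alone, compound 4 is reported only as "not active", with no number, so no step from compound 3 to compound 4 can be read. How far 2,3,4-trimethoxyphenyl in place of 4-fluorophenyl shifts the reading stays open, and nothing shown explains this result.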